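This account rests on a few compounds, and the source may have more. Where it says the series, first, only, none or still open, it means among the compounds named here.

Compound 1 `CCN1CCN(c2ccc(S(=O)(=O)Oc3cccc(OC)c3)cc2)C1=O` and compound 3 `CCCCN1CCN(c2ccc(S(=O)(=O)Oc3cccc(OC)c3)cc2)C1=O` share a sulfonate-linked scaffold and differ only at the saturated chain on the ring nitrogen: ethyl in place of hydrogen on a saturated chain carbon, two bonds along the chain from an amide-type nitrogen in a ring. In a functional assay on MCF7 cells (Homo sapiens) for antiproliferative activity, read by sulforhodamine B assay, with a stated time of 48 h (on this read-out lower numbers stand for stronger inhibition and higher numbers for weaker inhibition), compound 1 gives 14000 nM, while compound 3 gives 490 nM, so the step of a 29-fold lower number from compound 1 to compound 3 (1.46 log units; beyond the scatter) is the largest movement seen among these compounds.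

Compound 2 `CCN1CCN(c2ccc(S(=O)(=O)Oc3cccc(F)c3)cc2)C1=O` carries the core of compound 1 with fluoro in place of methoxy on an aromatic carbon. For compound 2 this assay reports only a limit, > 100000 nM, which is the assay limit described by the limit of > 100000 nM in this assay, at which 1 of the 3 values shown sits. The step of an at least 7.1-fold higher number from compound 1 to compound 2 (0.85 log units; beyond the scatter) therefore weakens the compound, though how far cannot be told from a limit.

Compound 4 `CCCCN1CCN(c2ccc(S(=O)(=O)Oc3cccc(F)c3)cc2)C1=O` is not yet measured. It stands to compound 3 exactly as compound 2 stands to compound 1: fluoro in place of methoxy on an aromatic carbon, the same change at the same place. On that pairing the expected step from compound 3 is a 10-fold higher number from compound 3 to compound 4 (1.01 log units; beyond the scatter), resting on the weakening already seen in an at least 7.1-fold higher number from compound 1 to compound 2 (0.85 log units; beyond the scatter). Compound 4 is thus expected to give about 5000 nM in this assay, estimated to lie between 1500 nM and 30000 nM.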

Compound 4, half-maximal inhibitory concentration: 310 nM
For compound 4 the middle estimate is 16-fold (1.21 log units) above the measured one; the whole stated range lies above it.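

In this assay, fluoro in place of methoxy on the core of compound 3 gives a 1.6-fold lower number from compound 3 to compound 4 (0.20 log units; within the scatter), which does not repeat the weakening seen on the core of compound 1: the same change on two cores in this assay, an at least 7.1-fold higher number (0.85 log units; beyond the scatter) from compound 1 to compound 2 and a 1.6-fold lower number (0.20 log units; within the scatter) from compound 3 to compound 4, at least 11-fold (1.05 log units) apart, beyond the scatter of two such steps

Read the other way, the chain change gives an at least 320-fold lower number from compound 2 to compound 4 (2.50 log units; beyond the scatter), and this too does not match its counterpart on the methoxy compounds: the same change on two cores in this assay, a 29-fold lower number (1.46 log units; beyond the scatter) from compound 1 to compound 3 and an at least 320-fold lower number (2.50 log units; beyond the scatter) from compound 2 to compound 4, at least 11-fold (1.05 log units) apart, beyond the scatter of two such steps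

So in these four compounds neither change carries over unaltered from one core to the other, but the size of the mismatch stays open, as compound 2 is known only by a limit, > 100000 nM, and a single pair of cores gives no general rule.

The compounds shown leave open how the fluoro and methoxy groups would compare on a propyl chain, on a longer chain, or on a chain ending in an amine. They also leave open whether chloro or hydroxy on the same aromatic carbon would follow either group.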